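The source may hold more compounds than are shown below. What is called first, only, known or untested is meant among the compounds shown, and "the series" means these compounds.

Going by the values given here, compound 3, whose structure is `CNc1nc(/C=C/c2cc(OC)c(OC)c(OC)c2)nc2ccsc12`, is one of three compounds measured so far in a functional assay on L02 cells (Homo sapiens) for inhibition, read by Griess assay, with stated times of 1 h and 24 h; a lower number here means a stronger inhibitor, a higher number a weaker inhibitor. For compound 3 the result is only a limit, > 1000000 nM, which is the weakest reading this assay can report. Compound 2, with structure `Brc1ccc(Nc2nc(/C=C/c3ccccc3)nc3ccsc23)cc1`, is also at that limit, giving > 1000000 nM in this assay. Two of the three measured values therefore sit at the same boundary, as stated in the limit of > 1000000 nM in this assay, at which 2 of the 3 values shown sit. Among the compounds with values here, compound 1, whose structure is `COc1cc(/C=C/c2nccc(NC(C)C)n2)cc(OC)c1OC`, is different: in this assay compound 1 gives < 40000 nM, again a limit rather than a number, and the limit of < 40000 nM in this assay, at which 1 of the 3 values shown sits, records that it is the only value at this end. Compound 1 shares with compound 3 the trimethoxy-substituted styryl part but not the core, so the two values cannot be compared as a single change.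

The unmeasured compound 4 has the structure `COc1cc(/C=C/c2nc(NCc3ccncc3)c3sccc3n2)cc(OC)c1OC`. It keeps the core of compound 3 and differs from compound 3 by pyridin-4-yl in place of hydrogen on a saturated chain carbon bound to a nitrogen on an aromatic ring. Within the data shown here, no measured pair with a comparable change is available, so the direction of the step is unknown. The core of compound 3 is shared with compound 2, and both gave only a limit in this assay, which weighs against a large gain. The step from compound 3 to compound 4 is expected to be an at least 1.6-fold lower number from compound 3 to compound 4 (0.22 log units; that floor lies within the scatter), within the scatter. Compound 4 is therefore expected to give about 600000 nM in this assay, with a likely range from 150000 nM to 2000000 nM.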

Compound 4, half-maximal inhibitory concentration: 374000 nM
Compound 4: the middle estimate sits 1.6-fold (0.21 log units) above what was measured; low and high end bracket the measured number.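

In this assay, putting pyridin-4-yl in place of hydrogen on a saturated chain carbon bound to a nitrogen on an aromatic ring, which turns methylamino into ((pyridin-4-yl)methyl)amino, gives an at least 2.6-fold lower number from compound 3 to compound 4 (0.42 log units; beyond the scatter). Among the compounds shown, compound 4 is the first with this core to give a real number and not a limit, so a change at this one place can lift a compound off the weak boundary of the assay. Only a minimum can be stated for the size of this step, because compound 3 has a limit and not a number as its starting point: the limit of > 1000000 nM in this assay, at which 2 of the 4 values shown sit.

With only one substituted group at this position, the compounds shown cannot tell whether the step depends on the ring nitrogen of pyridin-4-yl, the ring itself or simply a larger group, a question that a plain benzyl group, a pyridin-3-yl group or a longer chain could begin to answer. The core of compound 1 differs from that of compound 4, so how much the core contributes cannot be read from these compounds.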